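The source may hold more compounds than are shown below. What is called first, only, known or untested is meant among the compounds shown, and "the series" means these compounds.

In a functional assay on HepG2 cells (Homo sapiens) for cytotoxicity, read by MTT assay, with a stated time of 48 h (on this read-out higher numbers stand for weaker inhibition and lower numbers for stronger inhibition), compound 1 `Cc1n[nH]c2c1C(c1ccc(N(C)C)cc1)C(C(=O)NN)=C(N)N2` gives 66400 nM. Among the measured compounds shown here, compound 2 `Cc1n[nH]c2c1C(c1ccc(N(C)C)cc1)C(C(=O)n1ncc(C#N)c1N)=C(N)N2` gives 66300 nM, so it stands level with compound 1, its only measured neighbour, and the two numbers cannot be told apart. Compound 3 `Cc1n[nH]c2c1C(c1ccc(N(C)C)cc1)C(C(=O)N/N=C/c1ccc(Cl)cc1)=C(N)N2`, not yet measured, keeps the shared core and differs from compound 2 only in the group on a carbonyl carbon: a group of 10 heavy atoms (7 carbon, 2 nitrogen, 1 chlorine; one six-membered aromatic ring of carbon only) in place of a group of 8 heavy atoms (4 carbon, 4 nitrogen; one five-membered aromatic ring with 2 hetero atoms), on a carbonyl carbon. For the measured compounds named here, the one measured step that bears on this is a 1.0-fold lower number from compound 1 to compound 2 (0.00 log units; within the scatter), an exchange at the same place that stays within the scatter. The group entering compound 3 is unlike either group measured so far, with its six-membered aromatic ring of carbon only and its chlorine, so this single step is thin guidance. Still, it offers no ground for expecting a large move. In this assay the expected change is a 1.5-fold lower number from compound 2 to compound 3 (0.17 log units; within the scatter), which means no expected step beyond the scatter, although the uncertainty is wide. Compound 3 is estimated at 45000 nM, with an expected range from 12000 nM to 120000 nM.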

Compound 3, half-maximal inhibitory concentration: 39500 nM
Beside the measured number, compound 3's estimate is 1.1-fold (0.06 log units) above it, within the range that was stated.
By their numbers in this assay, from the lowest: compounds 3, 2 and 1 (each within the scatter of the next).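

In this assay, the place on a carbonyl carbon has now carried a third kind of group, one with a six-membered aromatic ring of carbon only and a chlorine, and the step stays within the scatter: a 1.7-fold lower number from compound 2 to compound 3 (0.22 log units; within the scatter), and likewise a 1.7-fold lower number from compound 1 to compound 3 (0.23 log units; within the scatter). The earlier pair had shown this only for an exchange between the amino group and 5-amino-4-cyano-1H-pyrazol-1-yl, whereas the three compounds now show it for a group with a different ring, a chlorine and a single hydrogen-bond acceptor, and none of the three goes against it. The data shown offer nothing that would account for the numbers staying together.

On these data alone, it remains open whether any group at this place can move the number beyond the scatter, as a morpholine or a longer alkyl chain on the carbonyl carbon might or might not do. As far as these compounds go, it is also open whether the chlorine itself has any bearing on the value, which only a version of the entering group with a methoxy group or a hydrogen in place of the chlorine could tell.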